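Ethyl to methyl on two amine-bearing cores, paw edema

This account rests on a few compounds, and the source may have more. Where it says the series, first, only, none or still open, it means among the compounds named here.

Measured compounds:
compound 1 `CNc1nnc(Cn2c(=O)oc3ccc(C)cc32)s1` — 46.9%
compound 2 `CCNc1nnc(Cn2c(=O)oc3ccc(C)cc32)s1` — 71.3%
compound 3 `CCNC(=S)NNC(=O)Cn1c(=O)oc2ccc(C)cc21` — 54.6%

In a functional assay on the whole organism for inhibition, with Mus musculus as the target, read by paw edema, with a stated time of 180 min, at a dose of 200 mg/kg by the oral route (a higher number here means a stronger effect of the compound at the dose given, a lower number a weaker effect), compound 2 gives 71.3%, and its steps to both other measured compounds lie beyond the scatter. Compound 1 and compound 3 sit within the scatter of each other, so no order between them is read. For the measured compounds named here, the one counted step is a number 24.4 percentage points lower from compound 2 to compound 1 (beyond the scatter); the change behind it is hydrogen in place of methyl on a saturated chain carbon bound to a nitrogen on an aromatic ring. The cores of compound 2 and compound 3 differ in more than one place, and that difference is not broken down here.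

Compound 4 `CNC(=S)NNC(=O)Cn1c(=O)oc2ccc(C)cc21` is not yet measured. It stands to compound 3 as compound 1 stands to compound 2: the change is hydrogen in place of methyl on a saturated chain carbon bound to an amide-type nitrogen. The two places are not the same word for word. In the measured pair the carbon is bound to a nitrogen on an aromatic ring; in the new pair it is bound to an amide-type nitrogen. Going by the values given here, it is therefore the same kind of change, made on a different core, and the measured step is the only guide to its size.

For compound 4 the step is expected to be a number 18.6 percentage points lower from compound 3 to compound 4 (beyond the scatter), taken to be similar to but less certain than the measured one because a number 24.4 percentage points lower from compound 2 to compound 1 (beyond the scatter) comes from a different core. Compound 4 is thus estimated at 36%, with a range from 20% to 54%.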

Compound 4, a percentage reported as inhibition, in the whole organism at one dose (the size of the read-out at that dose, not a potency): 71.6%
Estimate against measurement, compound 4: 35.6 percentage points below; the measured number lies above the stated range.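

Ethyl to methyl, the same change on the core of compound 3, gives a number 17 percentage points higher from compound 3 to compound 4 (beyond the scatter) in this assay, so here the read-out rises, while on the core of compound 2 it falls. The change therefore does not carry its direction from one core to the other in this series, and a step measured on one of these cores is no guide to the step on the other: the same change on two cores in this assay, a number 24.4 percentage points lower (beyond the scatter) from compound 2 to compound 1 and a number 17 percentage points higher (beyond the scatter) from compound 3 to compound 4, 41.4 percentage points apart, beyond the scatter of two such steps This rests on two pairs only, read at a single oral dose and a single time, so it shows that the outcome of this change depends on the core for these two cores, but it gives no cause for the reversal, no potency and no rule for any further core.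

The compounds shown leave open whether a longer chain such as propyl, or a branched one such as isopropyl, would raise or lower the read-out on either core, since two chain lengths per core define no trend. Also open, as far as these compounds go, is how an unsubstituted amino group or a cyclic amine such as morpholine, in place of ethylamino, would read on the two cores.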